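The source may hold more compounds than are shown below. What is called first, only, known or untested is meant among the compounds shown, and "the series" means these compounds.

Measured in an ADME assay on L6 cells (Rattus norvegicus) for cytotoxicity, read by resazurin assay, with a stated time of 72 h; a higher number here means a weaker inhibitor, a lower number a stronger inhibitor:
- compound 1 `N=C(N)c1ccc(COc2ccccc2)cc1`: 167000000 nM
- compound 2 `COc1ccc(OCc2ccc(C(=N)N)cc2)cc1`: 143000000 nM

Going by the values given here, compound 1 has no separate standing, as the only measured step is a 1.2-fold lower number from compound 1 to compound 2 (0.07 log units; within the scatter). Compound 3 `N=C(N)c1ccc(COc2cccc(C(=N)N)c2)cc1` differs from compound 1 by a group of 3 heavy atoms (1 carbon, 2 nitrogen; no ring) in place of a hydrogen atom, on an aromatic carbon, meta to a large group. Among the compounds with values here, the methoxy step to compound 2 bears on this only loosely, as it brings in a different group, and no measured step tests the entering group. A modest move to a lower number in this assay is expected, on weak evidence. The expected step is a 2.8-fold lower number from compound 1 to compound 3 (0.44 log units; beyond the scatter). For compound 3 the estimate is 60000000 nM, with an expected range of 8000000 nM to 200000000 nM.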

Compound 3, half-maximal inhibitory concentration: 19300000 nM
For compound 3 the middle estimate is 3.1-fold (0.49 log units) above the measured one, and the stated range covers the measured number.
By their numbers in this assay, from the lowest: compound 3; then compounds 2 and 1 (each within the scatter of the next).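

In this assay, the group of 3 heavy atoms on an aromatic carbon, meta to a large group, gives an 8.7-fold lower number from compound 1 to compound 3 (0.94 log units; beyond the scatter). Going by these compounds alone, this is the first single change to move the number beyond the scatter, as the methoxy step from the earlier pair stayed within it. No measurement shown accounts for this shift.

Going by these compounds, whether an amine or a carboxylic acid on this same carbon would move the number as far remains open. On these data alone, it also remains open how much of the step belongs to this position and how much to the entering group.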